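This account rests on a few compounds, and the source may have more. Where it says the series, first, only, none or still open, it means among the compounds named here.

Measured so far, all in a functional assay on MCF7 cells (Homo sapiens) for antiproliferative activity, read by MTT assay, with a stated time of 48 h; on this read-out lower numbers stand for stronger inhibition and higher numbers for weaker inhibition
Compound 1 `CN1CCN(CC(=O)Nc2ccc3ncnc(Nc4ccc(Cl)cc4)c3c2)CC1` gives 15000 nM
Compound 2 `CN1CCN(CC(=O)Nc2ccc3ncnc(Nc4cccc(Br)c4)c3c2)CC1` gives 10000 nM
Compound 3 `O=C(CN1CCCCC1)Nc1ccc2ncnc(Nc3ccc(Cl)c(C(F)(F)F)c3)c2c1` gives > 100000 nM

Compound 3 gives a limit and not a number (the limit of > 100000 nM in this assay, at which 1 of the 3 values shown sits). Compound 4 `CN1CCN(CC(=O)Nc2ccc3ncnc(Nc4ccc(Cl)c(C(F)(F)F)c4)c3c2)CC1` keeps everything in compound 3 except one group, with 4-methylpiperazin-1-yl in place of piperidin-1-yl on a saturated chain carbon bound to a carbonyl carbon.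

Within the data shown here, no measured step covers this swap directly. Among the measured compounds shown here, the only step available (a 1.5-fold lower number from compound 1 to compound 2 (0.18 log units; within the scatter)) changes a different group, the one on a nitrogen on an aromatic ring, so it sets no size for this change. Still, compound 1 and compound 2 both carry 4-methylpiperazin-1-yl and both return real numbers, with compound 1 at 15000 nM and compound 2 at 10000 nM in the same test. Compound 4 pairs that group with the other group of compound 3, however, so the numbers of compound 1 and compound 2 are only a loose guide. A move towards a lower number, meaning stronger inhibition, is expected, though compound 4 could also stay at the limit. The estimated step is an at least 4.0-fold lower number from compound 3 to compound 4 (0.60 log units; beyond the scatter) and its size is uncertain. For compound 4 the estimate is 25000 nM with an expected range from 6000 nM to 100000 nM in this assay for now.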

Compound 4, half-maximal inhibitory concentration: > 100000 nM
Compound 4: no number, only a limit; the forecaster's own chance of this, stated with the estimate: 20%; middle value at least 4.0-fold (0.60 log units) away from the limit.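

In this assay compound 4 gives > 100000 nM, which is a limit and not a number, so the step between compound 3 and compound 4 cannot be read, and 4-methylpiperazin-1-yl in place of piperidin-1-yl does not lift this aromatic group off the limit: the limit of > 100000 nM in this assay, at which 2 of the 4 values shown sit.

The new information comes from the group on a nitrogen on an aromatic ring, which mattered little in the earlier pair but now clearly counts with 4-methylpiperazin-1-yl held fixed: 4-chloro-3-(trifluoromethyl)phenyl in place of 3-bromophenyl gives an at least 10-fold higher number from compound 2 to compound 4 (1.00 log units; beyond the scatter). Trifluoromethyl in place of hydrogen on an aromatic carbon gives an at least 6.6-fold higher number from compound 1 to compound 4 (0.82 log units; beyond the scatter), so this one added group is enough to take the compound from a measurable value to the limit.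

The compounds shown give no pair with a real number on both sides of the piperidin-1-yl change, so its effect remains unknown, and a piperidin-1-yl compound carrying 4-chlorophenyl or 3-bromophenyl could settle it. Going by these compounds, it also remains open whether a methyl group or a fluorine atom in place of trifluoromethyl would keep a measurable value, and what morpholin-4-yl would do on the saturated chain carbon.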